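A Cyclic Amine in Place of Dimethylamino

This account rests on a few compounds, and the source may have more. Where it says the series, first, only, none or still open, it means among the compounds named here.

Three compounds share one core and differ at a single aromatic carbon. In a functional assay on CHO-K1 cells for antagonist activity at transient receptor potential cation channel subfamily V member 1 (Homo sapiens), read by FLIPR (on this read-out higher numbers stand for weaker inhibition and lower numbers for stronger inhibition), compound 1 `CC(C(=O)NCc1ccc(C(F)(F)F)nc1NC1CCCCC1)c1ccc(NS(C)(=O)=O)c(F)c1` gives 260 nM, compound 2 `CC1CCC(Nc2nc(C(F)(F)F)ccc2CNC(=O)C(C)c2ccc(NS(C)(=O)=O)c(F)c2)CC1` gives 1130 nM, and compound 3 `CC(C(=O)NCc1ccc(C(F)(F)F)nc1N(C)C)c1ccc(NS(C)(=O)=O)c(F)c1` gives 2390 nM, the highest number of the three. Compound 4 `CC(C(=O)NCc1ccc(C(F)(F)F)nc1N1CC=CCC1)c1ccc(NS(C)(=O)=O)c(F)c1` differs from compound 3 by a group of 6 heavy atoms (5 carbon, 1 nitrogen; one six-membered non-aromatic ring with 1 hetero atom) in place of a group of 3 heavy atoms (2 carbon, 1 nitrogen; no ring), on an aromatic carbon. Among the compounds with values here, the steps that bear on this are a 9.2-fold higher number from compound 1 to compound 3 (0.96 log units; beyond the scatter) and a 2.1-fold higher number from compound 2 to compound 3 (0.33 log units; beyond the scatter): losing a six-membered ring at this position raised the number both times. Compound 4 brings back a six-membered ring, though not the same one as in compound 1. A lower number is therefore expected for compound 4, with a step estimated as a 3.0-fold lower number from compound 3 to compound 4 (0.48 log units; beyond the scatter). In this assay compound 4 is expected to give about 800 nM, within a range from 250 nM to 2500 nM.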

Compound 4, half-maximal inhibitory concentration: 12.1 nM
Estimate against measurement, compound 4: 66-fold (1.82 log units) above; the whole stated range lies above it.
By their numbers in this assay, from the lowest: compound 4; then compound 1; then compound 2; then compound 3.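

The six-membered ring with one hetero atom and one double bond gives a 200-fold lower number from compound 3 to compound 4 (2.30 log units; beyond the scatter) and so does far more than restore a ring at this aromatic carbon. It also beats both carbon-only rings, with a 93-fold lower number from compound 2 to compound 4 (1.97 log units; beyond the scatter) and a 21-fold lower number from compound 1 to compound 4 (1.33 log units; beyond the scatter), which shows that the kind of ring here counts, not just the presence of one. Nothing measured here explains this gain. The compounds shown leave open what the same six-membered ring would give without its double bond, and what a five-membered ring with one nitrogen would give.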